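A few compounds are considered here, and "the series" means these few. Any claim that something is new, unique, unknown or untested is made for them only; others in the source may bear on it.

Measured so far:
compound 1, `CCOC(=O)/C(CCCC(=O)O)=N\Nc1ccc(Cl)cc1`, 20000 nM;
compound 2, `CCOC(=O)/C(CCCC(=O)O)=N\Nc1ccc(Br)cc1`, 21000 nM;
compound 3, `CCOC(=O)/C(CCCC(=O)O)=N\Nc1ccc(C)cc1`, 33000 nM.

All three numbers come from an assay on isolated protein for inhibition of kynurenine--oxoglutarate transaminase 1 (Homo sapiens), read by HPLC, with a stated time of 20 min; a lower number here means a stronger inhibitor, a higher number a weaker inhibitor. The three values lie close together: the step of a 1.1-fold higher number from compound 1 to compound 2 (0.02 log units; within the scatter) is within the scatter, as are a 1.7-fold higher number from compound 1 to compound 3 (0.22 log units; within the scatter) and a 1.6-fold higher number from compound 2 to compound 3 (0.20 log units; within the scatter). Compound 3 therefore stands within the scatter of both compound 1 and compound 2, and none of the three can be called stronger or weaker than the others.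

The unmeasured compound 4, `CCOC(=O)/C(CCCC(=O)O)=N\Nc1cccc(Cl)c1`, differs from compound 3 by 3-chlorophenyl in place of 4-methylphenyl on an amine nitrogen. Of the measured steps, a 1.7-fold higher number from compound 1 to compound 3 (0.22 log units; within the scatter) bears on it most directly, since it exchanges a chloro for a methyl on the aromatic ring and stays within the scatter; a 1.6-fold higher number from compound 2 to compound 3 (0.20 log units; within the scatter) points the same way. Within the data shown here, no measured step exchanges the 4-substituted phenyl for a 3-substituted one, so that part of the change is uncharted. On these grounds a step of no more than the scatter is expected in this assay, with the wider uncertainty of the untested position shift. Compound 4 is estimated at 25000 nM, with a range from 9000 nM to 70000 nM, which means an expected step of a 1.3-fold lower number from compound 3 to compound 4 (0.12 log units; within the scatter).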

Compound 4, half-maximal inhibitory concentration: 20000 nM
Compound 4: middle estimate off by 1.3-fold (0.10 log units), on the high side; low and high end bracket the measured number.
By their numbers in this assay, from the lowest: compounds 1, 4, 2 and 3 (each within the scatter of the next).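

In this assay, among these compounds, the result gives a first reading on the place of the substituent on the aromatic ring, which no earlier step covered: changing only the place of the chloro gives no change at the digits printed from compound 1 to compound 4 (within the scatter) for this position. The other two comparisons agree, with a 1.1-fold lower number from compound 2 to compound 4 (0.02 log units; within the scatter) and a 1.7-fold lower number from compound 3 to compound 4 (0.22 log units; within the scatter) both staying inside the scatter, so among these four compounds neither the kind of group nor the place of the chloro separates one value from another. No measured evidence accompanies these numbers to account for how little they differ.

The compounds shown leave open whether 3-bromophenyl or 3-methylphenyl would stay within the same narrow band as 3-chlorophenyl does. They also leave open whether a carboxylic acid or an amine on the aromatic ring, or a longer chain in place of the one that carries the acid in the shared core, would produce any step beyond the scatter in this assay at all.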